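Swapping a fluorophenyl for a chlorinated pyridinone ring

This account rests on a few compounds, and the source may have more. Where it says the series, first, only, none or still open, it means among the compounds named here.

Compound 1 `CCCCc1nc(=O)c(S(=O)(=O)c2ccc(-c3ccc(F)cc3)cc2)c(O)n1-c1c(OC)cccc1OC` is the starting point. Within the data shown here, in an ADME assay on microsomes from liver (Mus musculus) for metabolic stability, using NADPH, with a stated time of 10 min (a lower number here means that less of the compound is left, a higher number that more of the compound is left), compound 1 gives 47%, the lowest of the three numbers measured so far. Compound 2 `CCCCc1nc(=O)c(S(=O)(=O)c2ccc(-c3cccnc3)cc2)c(O)n1-c1c(OC)cccc1OC` gives 57% in this assay, and compound 3 `CCCCc1nc(=O)c(S(=O)(=O)c2ccc(-n3ccccc3=O)cc2)c(O)n1-c1c(OC)cccc1OC` gives 63%. The step of a number 10 percentage points higher from compound 1 to compound 2 (within the scatter) stays within the scatter, while a number 16 percentage points higher from compound 1 to compound 3 (beyond the scatter) is a modest but genuine gain; between those two compounds, a number 6 percentage points higher from compound 2 to compound 3 (within the scatter) is again within the scatter.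

Compound 4 `CCCCc1nc(=O)c(S(=O)(=O)c2ccc(-n3cc(Cl)ccc3=O)cc2)c(O)n1-c1c(OC)cccc1OC` has not yet been measured. Relative to compound 1 the change is a group of 8 heavy atoms (5 carbon, 1 nitrogen, 1 oxygen, 1 chlorine; one six-membered aromatic ring with 1 hetero atom) in place of a group of 7 heavy atoms (6 carbon, 1 fluorine; one six-membered aromatic ring of carbon only), on an aromatic carbon. This closely resembles the change that led to compound 3: both replace the 4-fluorophenyl with a six-membered aromatic ring holding one nitrogen and an oxygen, and compound 4 carries an additional chlorine on that ring. Among the measured compounds shown here, the only measured step that bears on it directly is a number 16 percentage points higher from compound 1 to compound 3 (beyond the scatter); no measured pair shows what the chlorine alone does. The expected step of a number 13 percentage points higher from compound 1 to compound 4 (beyond the scatter) is therefore a modest rise in this assay, in the direction seen for compound 3, with the untested chlorine widening the uncertainty. Compound 4 is estimated at 60%, with a range from 45% to 75%.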

Compound 4, percent of the compound remaining: 100%
Beside the measured number, compound 4's estimate is 40 percentage points below it, outside the stated range (above it).
By their numbers in this assay, from the lowest: compounds 1, 2 and 3 (each within the scatter of the next, the first and the last beyond it); then compound 4.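

The single chlorine carries most of the effect at this position: with chloro in place of hydrogen on an aromatic carbon of the ring attached to the sulfonyl-bearing phenyl, this assay shows a number 37 percentage points higher from compound 3 to compound 4 (beyond the scatter), a large step that the first three compounds gave no way of seeing. Against the two other groups at the same place, the chlorinated ring also stands well clear, with a number 53 percentage points higher from compound 1 to compound 4 (beyond the scatter) when it replaces 4-fluorophenyl and a number 43 percentage points higher from compound 2 to compound 4 (beyond the scatter) when it replaces pyridin-3-yl, so a small edit to a ring already in place did far more here than exchanging one ring for another had done among compounds 1, 2 and 3. Nothing available here gives a reason for the size of this chlorine step.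

The compounds shown leave open whether a fluoro, a bromo, a methyl or a methoxy group on the same ring would have a similar effect, or whether the effect belongs to chlorine alone. They also leave open whether a chloro group added to the 4-fluorophenyl or pyridin-3-yl ring would give a similar rise, or whether it depends on the ring that enters in compound 4.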